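The compounds below may be only part of what the source reports. "The series", "measured", "known", "first", "only" and "open" are said of these compounds alone.

Measured in an ADME assay on MT4 cells (Homo sapiens) for cytotoxicity, read by MTT assay, with a stated time of 96 h; a higher number here means that more compound is tolerated, a lower number that less compound is tolerated:
- compound 1 `NS(=O)(=O)c1ccc(N2N=C(c3ccccc3)CC2c2ccccc2Cl)cc1`: 44000 nM
- compound 2 `NS(=O)(=O)c1ccc(N2N=C(c3ccc(Oc4ccccc4)cc3)CC2c2cccc(F)c2)cc1`: 25000 nM
- compound 3 `NS(=O)(=O)c1ccc(N2N=C(c3ccc(OCc4ccccc4)cc3)CC2c2cccc(F)c2)cc1`: 65000 nM

Compound 2 lies within the scatter of compound 1, while compound 3 stands beyond the scatter from it. Among the compounds with values here, the only measured step is modest: a 2.6-fold higher number from compound 2 to compound 3 (0.41 log units; beyond the scatter). That step is benzyl in place of phenyl on an oxygen on an aromatic ring.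

Compound 4 `NS(=O)(=O)c1ccc(N2N=C(c3ccc(Oc4ccccc4)cc3)CC2c2ccccc2F)cc1` keeps the atoms of compound 2 but carries 2-fluorophenyl in place of 3-fluorophenyl on a saturated ring carbon. Within the data shown here, no measured step touches this place, so the one available step serves only as a gauge of size in this assay. No change beyond the scatter is expected, and the expected step is a 1.1-fold higher number from compound 2 to compound 4 (0.03 log units; within the scatter). Compound 4 is estimated at 27000 nM, with an expected range from 13000 nM to 55000 nM.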

Compound 4, half-maximal cytotoxic concentration: 36000 nM
The estimate for compound 4 lay 1.3-fold (0.12 log units) below the measured number; the measured number falls inside the stated range.
By their numbers in this assay, from the lowest: compounds 2, 4, 1 and 3 (each within the scatter of the next, the first and the last beyond it).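

Within the data shown here, the first change at this place, 2-fluorophenyl in place of 3-fluorophenyl on a saturated ring carbon, gives in this assay a 1.4-fold higher number from compound 2 to compound 4 (0.16 log units; within the scatter). The two fluorophenyl groups therefore cannot be told apart here, at least with phenyl on the oxygen, and the swap gives no sign that this assay responds to where the fluorine sits. Nothing measured on these compounds bears on this result. As far as these compounds go, it remains open whether an amine or a methoxy group on this phenyl ring would move the number beyond the scatter. From the compounds shown here alone, it is also open whether the same swap behaves alike with benzyl on the oxygen.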